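Fluorine on the Terminal Methyl of a Difluoro Alcohol

This account rests on a few compounds, and the source may have more. Where it says the series, first, only, none or still open, it means among the compounds named here.

Compound 1 `CC(F)(F)CCCO`: 0.71
Compound 2 `CC(=O)N1CCC[C@H]1C(=O)OCC(F)(F)F`: 0.55

Of the compounds shown here, two have numbers so far in a physicochemical assay for lipophilicity, read by NMR; a lower number here means a more polar compound, a higher number a more lipophilic compound. Compound 1 gives 0.71 in this assay, and compound 2 gives 0.55, the two values lying within the scatter of each other. Compound 3 `OCCCC(F)(F)CF` has not yet been measured. It differs from compound 1 by fluoro in place of hydrogen on a saturated chain carbon, two bonds along the chain from two fluorine atoms. Within the data shown here, with no step between measured compounds to lean on, a small shift toward the polar side, if anything beyond the scatter, is expected, so that the step of a number 0.21 log units lower from compound 1 to compound 3 (within the scatter) is estimated. Compound 3 is thus expected to give 0.5, within 0.2 to 0.8.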

Compound 3, partition coefficient: 0.58
Compound 3: the middle estimate sits 0.08 log units below what was measured, within the range that was stated.
By their numbers in this assay, from the lowest: compounds 2, 3 and 1 (each within the scatter of the next).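

In this assay, among these compounds, fluoro in place of hydrogen on a saturated chain carbon, two bonds along the chain from two fluorine atoms, gives a number 0.13 log units lower from compound 1 to compound 3 (within the scatter), the first step that can be read at this position. This single replacement, methyl to fluoromethyl, therefore does not separate the two compounds beyond the usual scatter. No independent measurement bears on this result.

Going by these compounds, whether a trifluoromethyl group at the same position would give a step beyond the scatter remains open. So does whether the fluoromethyl step would stay as small on a longer chain, or with an amine or a carboxylic acid at the other end.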